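Adding Bromine to the Shared Core: What to Expect

This account rests on a few compounds, and the source may have more. Where it says the series, first, only, none or still open, it means among the compounds named here.

Compound 1 `Clc1cccc(NCc2nc3ccccc3[nH]2)c1` gives 44.4% in a functional assay on the whole organism (strain albino) for inhibition, with Rattus norvegicus as the target, read by paw edema, with a stated time of 180 min, at a dose of 100 mg/kg by the oral route; a lower number here means less inhibition, a higher number more inhibition at the dose given (going by the name of the read-out).
Compound 2 `c1ccc(NCc2nc3ccccc3[nH]2)cc1` gives 38.8% in this assay.

The two measured compounds share one core and differ in a single spot: hydrogen in place of chloro on an aromatic carbon, giving a number 5.6 percentage points lower from compound 1 to compound 2 (within the scatter). Compound 2 thus holds the lower of the two numbers, but its gap to compound 1 lies within the scatter, so the two cannot be told apart on this evidence.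

Compound 3 `Brc1ccc2nc(CNc3ccccc3)[nH]c2c1` is not yet measured. It differs from compound 2 by bromo in place of hydrogen on an aromatic carbon. Within the data shown here, the one measured step concerns a halogen on a different ring of the molecule and was itself within the scatter, so no measured step bears directly on this new change. With nothing pointing either way, the expected step in this assay is a number 1.2 percentage points higher from compound 2 to compound 3 (within the scatter), no larger than the scatter. On that basis compound 3 is estimated at 40%, with a likely range from 28% to 52%.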

Compound 3, a percentage reported as inhibition, in the whole organism at one dose (the size of the read-out at that dose, not a potency): 22.2%
Beside the measured number, compound 3's estimate is 17.8 percentage points above it, outside the stated range (below it).
By their numbers in this assay, from the lowest: compound 3; then compounds 2 and 1 (each within the scatter of the next).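

Bromo on the six-membered aromatic ring of carbon only, part of the fused system, is the first single change here that stands clear of the scatter: in this assay it gives a number 16.6 percentage points lower from compound 2 to compound 3 (beyond the scatter) and so moves the result towards less inhibition at the dose given. The earlier pair, with its halogen on a different ring, left open whether any single change could shift this read-out, whereas this step shows that one added heavy atom, with no hydrogen-bond donors or acceptors, at this place on the shared core is enough to do so. No measurement shown here gives a reason for the drop.

Going by these compounds, with one group at one place, it remains open whether the drop belongs to bromo itself or to any substituent at this place, which fluoro, chloro, methyl, methoxy, an amine or a carboxylic acid at the same carbon could help to settle. On these data alone, it is also open whether bromo on the other ring would give a similar step, and whether the same gap would hold at other doses or times.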